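Fluoro Step Repeated on a Second Core

This account rests on a few compounds, and the source may have more. Where it says the series, first, only, none or still open, it means among the compounds named here.

Compound 1 `COc1cc2nc(Nc3ccc(S(C)(=O)=O)cc3)nc(OCC3CCN(C(=O)OC(C)(C)C)CC3)c2cc1OC` and compound 2 `COc1cc2nc(Nc3ccc(S(C)(=O)=O)cc3F)nc(OCC3CCN(C(=O)OC(C)(C)C)CC3)c2cc1OC` share one core; compound 3 `COc1cc2nc(N3CCC4CCC(C3)N4C(=O)OC(C)(C)C)nc(Nc3ccc(S(C)(=O)=O)cc3)c2cc1OC` and compound 4 `COc1cc2nc(N3CCC4CCC(C3)N4C(=O)OC(C)(C)C)nc(Nc3ccc(S(C)(=O)=O)cc3F)c2cc1OC` share another. The difference between the two cores is not broken down here. Within each pair the change is the same: fluoro in place of hydrogen on an aromatic carbon for the measured pair and fluoro in place of hydrogen on an aromatic carbon for the pair still open, and the surroundings of the place read the same word for word in both cases.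

In a functional assay on HEK293 cells for agonist activity at Glucose-dependent insulinotropic receptor (Homo sapiens), read by cAMP accumulation, with a stated time of 60 min (on this read-out lower numbers stand for an effect already at smaller amounts and higher numbers for an effect only at larger amounts of compound), compound 1 gives > 10000 nM, which is a limit of the assay and not a number. Compound 2 gives > 10000 nM, again a limit. Compound 3 gives > 10000 nM, also a limit. The step that the two limits leave unreadable from compound 1 to compound 2 is thus not readable in size, since both of its ends sit at the limit of > 10000 nM in this assay, at which 3 of the 3 values shown sit.

For compound 4 the expectation rests on compound 3 sitting at > 10000 nM. It rests further on the measured pair, where the same change left the value at the limit, a step that the two limits leave unreadable from compound 1 to compound 2. Compound 4 is expected to give 15000 nM, with a range of 5000 nM to 50000 nM, which means an expected step that the limit leaves unreadable from compound 3 to compound 4. It is expected that this assay will again report only a limit for compound 4 rather than a number.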

Compound 4, half-maximal effective concentration: 1000 nM
For compound 4 the middle estimate is 15-fold (1.18 log units) above the measured one; the measured number lies below the stated range.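

On the core of compound 3, fluoro in place of hydrogen on an aromatic carbon, which turns 4-(methylsulfonyl)phenyl into 2-fluoro-4-(methylsulfonyl)phenyl, gives in this assay an at least 10-fold lower number from compound 3 to compound 4 (1.00 log units; beyond the scatter), and this size is only a minimum, since the end at compound 3 is a limit of the assay and not a number. On the core of compound 1 the same change cannot be read, and the pair compound 1 and compound 2 therefore offers no size to set against the new step, since both of its ends stand at a limit of the assay: the limit of > 10000 nM in this assay, at which 3 of the 4 values shown sit. Among the compounds shown here, the series thus shows that this change can go with a clear step on one core, but it does not show that the step carries over from one core to the other, nor that it would have the same size on both, and compound 4 remains the only compound here with a number.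

Open, going by these compounds, is whether a chloro or a methyl in place of the fluoro gives a similar step on the core of compound 3. Also open, on these data alone, is whether a nitrile in place of the methylsulfonyl group, or a free amine in place of the tert-butoxycarbonyl group, keeps the read-out of compound 4 measurable.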